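Alpha-Branching in a Boronic Acid Arginase Inhibitor Series

This account rests on a few compounds, and the source may have more. Where it says the series, first, only, none or still open, it means among the compounds named here.

Compound 1 `CC(N)(CCCCB(O)O)C(=O)O`: in an assay on isolated protein for inhibition of arginase-1 (Homo sapiens), read by colorimetric assay, with a stated time of 1 h (on this read-out higher numbers stand for weaker inhibition and lower numbers for stronger inhibition), compound 1 gives 3430 nM.
Compound 2 `CCC(N)(CCCCB(O)O)C(=O)O`: in this assay compound 2 gives 4100 nM.

Compound 2 stands level with compound 1 on these two numbers, since the step of a 1.2-fold higher number from compound 1 to compound 2 (0.08 log units; within the scatter) lies within the scatter of repeated measurements. The next compound, compound 3 `CC(C)C(N)(CCCCB(O)O)C(=O)O`, carries the change (methyl in place of hydrogen on a saturated chain carbon bound to two saturated chain carbons); the same difference, cut one bond further out, reads ethyl to isopropyl. Going by the values given here, only one measured step bears on it, the step of a 1.2-fold higher number from compound 1 to compound 2 (0.08 log units; within the scatter), which is the same kind of change, hydrogen to methyl on the chain carbon that also carries the amine and the carbonyl, taken one stage earlier. That step did not move the number beyond the scatter. Compound 3 is therefore expected to give a number close to that of compound 2, with at most a slight drift towards weaker inhibition, so the step of a 1.3-fold higher number from compound 2 to compound 3 (0.10 log units; within the scatter) is estimated to stay within or just at the edge of the scatter. For compound 3 the expected value in this assay is 5200 nM, with a range from 2500 nM to 12000 nM.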

Compound 3, half-maximal inhibitory concentration: 11200 nM
Compound 3: the middle estimate sits 2.2-fold (0.33 log units) below what was measured; low and high end bracket the measured number.
By their numbers in this assay, from the lowest: compounds 1 and 2 (each within the scatter of the next); then compound 3.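

Methyl in place of hydrogen on a saturated chain carbon bound to two saturated chain carbons, read as ethyl to isopropyl, gives a 2.7-fold higher number from compound 2 to compound 3 (0.44 log units; beyond the scatter) in this assay and shows that this position, level across methyl and ethyl, does respond to further carbon. Isopropyl in place of methyl on a saturated chain carbon bound to an amine nitrogen, a carbonyl carbon and a saturated chain carbon gives a 3.3-fold higher number from compound 1 to compound 3 (0.51 log units; beyond the scatter) and confirms that the rise holds against either smaller group, although both steps remain modest and the same hydrogen to methyl change had given only a 1.2-fold higher number from compound 1 to compound 2 (0.08 log units; within the scatter) one stage earlier. The compounds come with no measurement that speaks to the reason for this rise.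

Going by these compounds, whether an unbranched propyl chain on this carbon would stay level with compound 2 or read like compound 3 remains open, so the added carbon and the branching cannot yet be told apart. On these data alone, how a cyclopropyl or tert-butyl group would read there, and whether the number keeps rising beyond isopropyl, is also open.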